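Pyrazoline thioureas: aryl swap at the imine carbon

The source may report more compounds than this note shows. Statements on the series, on what has been measured and on what is new or still open speak of the compounds shown alone.

Compound 2 `S=C(Nc1ccccc1)N1N=C(c2ccc(Cl)c(Cl)c2)CC1c1ccc2c(c1)OCCO2` gives the lowest of the two numbers in a functional assay on WM 266-4 cells (Homo sapiens) for antiproliferative activity, read by MTT assay, with a stated time of 48 h (a higher number here means a weaker inhibitor of growth, a lower number a stronger inhibitor of growth), namely 58700 nM. Its nearest neighbour is compound 1 `O=[N+]([O-])c1ccc(C2=NN(C(=S)Nc3ccccc3)C(c3ccc4c(c3)OCCO4)C2)cc1`, which in this assay gives 105000 nM; the step of a 1.8-fold lower number from compound 1 to compound 2 (0.25 log units; within the scatter) lies within the scatter, so the two compounds cannot be ranked against each other. Compound 3 `S=C(Nc1ccccc1)N1N=C(c2cccs2)CC1c1ccc2c(c1)OCCO2` is not yet measured and differs from compound 2 by thiophen-2-yl in place of 3,4-dichlorophenyl on a carbon with a double bond to nitrogen. Among the compounds with values here, the only measured step at this position, a 1.8-fold lower number from compound 1 to compound 2 (0.25 log units; within the scatter), is the exchange of one six-membered aromatic ring for another and did not move the number beyond the scatter; no measured step involves a thiophen-2-yl group, so its effect here is unknown. A change beyond the scatter is therefore not expected in either direction, and compound 3 is estimated at 70000 nM in this assay, with a range of 25000 nM to 200000 nM, the expected step being a 1.2-fold higher number from compound 2 to compound 3 (0.08 log units; within the scatter).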

Compound 3, concentration for 50% growth inhibition: 154000 nM
The estimate for compound 3 lay 2.2-fold (0.34 log units) below the measured number; measured number inside the range.
By their numbers in this assay, from the lowest: compounds 2, 1 and 3 (each within the scatter of the next, the first and the last beyond it).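

In this assay this position now gives a step beyond the scatter: thiophen-2-yl in place of 3,4-dichlorophenyl gives a 2.6-fold higher number from compound 2 to compound 3 (0.42 log units; beyond the scatter) and so the group on this carbon with a double bond to nitrogen can move the number, if only modestly. The exchange of 4-nitrophenyl for thiophen-2-yl gives a 1.5-fold higher number from compound 1 to compound 3 (0.17 log units; within the scatter) and does not separate those two compounds, so the five-membered sulfur-containing ring does not set itself apart from both six-membered aromatic rings. Nothing available accounts for the step between the 3,4-dichlorophenyl and thiophen-2-yl compounds.

Still open, on these data alone, is what a non-aromatic group at this position, such as cyclohexyl or an aminoalkyl chain, would do to the number. Also open, as far as these compounds go, is whether the step holds with another group in place of the 2,3-dihydro-1,4-benzodioxin-6-yl group.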